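A propyl ester among the adenine-bearing hydroxypropanoates

The source may report more compounds than this note shows. Statements on the series, on what has been measured and on what is new or still open speak of the compounds shown alone.

Compound 1 `CCCCCCCCOC(=O)C(O)Cn1cnc2c(N)ncnc21` gives 100 ug/mL in a functional assay on PRK cells (Oryctolagus cuniculus) for cytotoxicity; a lower number here means that less compound is tolerated, a higher number that more compound is tolerated.
Compound 2 `COCCOC(=O)C(O)Cn1cnc2c(N)ncnc21` gives > 400 ug/mL in this assay, a limit of the assay.
Compound 3 `CC(C)(C)OC(=O)C(O)Cn1cnc2c(N)ncnc21` gives > 400 ug/mL in this assay, a limit of the assay.

Compound 3 therefore stands at the top of what this assay can report, a position shared with compound 2 (the limit of > 400 ug/mL in this assay, at which 2 of the 3 values shown sit). Only compound 1, with its octyl group, returns a number. Compound 4 `CCCOC(=O)C(O)Cn1cnc2c(N)ncnc21` differs from compound 3 at a single place: propyl in place of tert-butyl on an oxygen next to a carbonyl group. The measured steps that bear on this change are the two that leave octyl at the same place, an at least 4.0-fold higher number from compound 1 to compound 3 (0.60 log units; beyond the scatter) and an at least 4.0-fold higher number from compound 1 to compound 2 (0.60 log units; beyond the scatter). The step between the two limit-bound compounds cannot be sized, a step that the two limits leave unreadable from compound 2 to compound 3. Propyl is a short chain, closer in size to tert-butyl than to octyl, so compound 4 is expected to sit at or near the limit as well, because an at least 4.0-fold higher number from compound 1 to compound 3 (0.60 log units; beyond the scatter) shows that a small group in this place is tolerated up to the limit. Compound 4 is thus expected to give 400 ug/mL, within 200 ug/mL to 800 ug/mL. This estimate means a number no higher from compound 3 to compound 4 (the limit leaves the size open), a step not expected to exceed the scatter.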

Compound 4, minimum cytotoxic concentration: 100 ug/mL
For compound 4 the middle estimate is 4.0-fold (0.60 log units) above the measured one, and the stated range ends above it.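

In this assay, the straight-chain propyl and octyl esters read alike, with no change at the digits printed from compound 1 to compound 4 (within the scatter), so shortening this chain does not by itself lift the number. The branched tert-butyl group behaves differently, giving an at least 4.0-fold lower number from compound 3 to compound 4 (0.60 log units; beyond the scatter), and swapping methoxy for methyl within the 2-methoxyethyl chain gives an at least 4.0-fold lower number from compound 2 to compound 4 (0.60 log units; beyond the scatter). Tolerance at this place therefore follows the kind of group and not simply its size, and the top of the scale, a limit and not a number, is held only by the tert-butyl and 2-methoxyethyl esters: the limit of > 400 ug/mL in this assay, at which 2 of the 4 values shown sit.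

Going by these compounds, whether another branched group, such as isopropyl, also reaches that limit remains open. So does the effect of an amine in place of the methoxy, and of straight chains shorter than propyl, such as ethyl.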